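This account rests on a few compounds, and the source may have more. Where it says the series, first, only, none or still open, it means among the compounds named here.

Measured so far:
Compound 1, `O=C1Nc2ccc(Br)cc2/C1=N/NC(=S)N/N=C/c1ccc2ccccc2c1` — > 50000 nM
Compound 2, `COc1ccc(/C=N/NC(=S)N/N=C2\C(=O)Nc3ccc(Br)cc32)c(OC)c1` — > 50000 nM
Compound 3, `COc1ccc(/C=N/NC(=S)N/N=C2\C(=O)Nc3ccc(C)cc32)c(OC)c1` — > 50000 nM

All three values come from a functional assay on COS-7 cells (Chlorocebus aethiops) for inhibition, read by MTT assay; a higher number here means a weaker inhibitor, a lower number a stronger inhibitor. For compound 1 the value > 50000 nM is a limit of the assay, not a number. For compound 2 the value > 50000 nM is likewise a limit. For compound 3 the value > 50000 nM is a limit as well. All three therefore sit at the limit of > 50000 nM in this assay, at which 3 of the 3 values shown sit, and no real difference between them can be read.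

Compound 2 and compound 3 differ in one place: methyl in place of bromo on an aromatic carbon. The resulting step that the two limits leave unreadable from compound 2 to compound 3 cannot be sized, since both ends are limits. Compound 1 and compound 2 share the rest of their structure apart from a larger part that is not broken down here.

The compound not yet measured is compound 4, `Cc1ccc2c(c1)/C(=N/NC(=S)N/N=C/c1ccc3ccccc3c1)C(=O)N2`. It arises from compound 1 by methyl in place of bromo on an aromatic carbon, the same change that turns compound 2 into compound 3, at the same place. Because compound 1 sits at the limit of > 50000 nM in this assay, at which 3 of the 3 values shown sit, and because the step that the two limits leave unreadable from compound 2 to compound 3 gave no readable shift, compound 4 is expected to remain weak. Compound 4 is estimated at 80000 nM, most likely between 30000 nM and 300000 nM. The expected step is a step that the limit leaves unreadable from compound 1 to compound 4, which means essentially no change, most probably reported again only as a limit.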

Compound 4, half-maximal inhibitory concentration: > 50000 nM
Compound 4 gave a limit, no number; the forecaster's own chance of this, stated with the estimate: 90%; the middle value lies beyond the limit too.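

In this assay compound 4 gives > 50000 nM, which is a limit and not a number. Compound 1 also stands at a limit, and no new step can be read between compound 1 and compound 4. All the compounds shown end up at the same reading: the limit of > 50000 nM in this assay, at which 4 of the 4 values shown sit.

The compounds shown leave open whether methyl in place of bromo changes inhibition at all, as none of them gives an actual number to compare.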